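Benzyl in Place of Chloropyridinylmethyl: an Expected Shift

The compounds below may be only part of what the source reports. "The series", "measured", "known", "first", "only" and "open" are said of these compounds alone.

Compound 2 `O=C(N/N=C/c1ccccc1O)c1cc(-c2ccccc2)nn1Cc1ccc(Cl)nc1` gives 45000 nM in a functional assay on A549 cells (Homo sapiens) for cytotoxicity, read by MTT assay, with a stated time of 48 h (a lower number here means a less soluble compound, a higher number a more soluble compound), the second highest of the three numbers available. Among the compounds with values here, its nearest neighbour is compound 3 `COc1ccc(-c2cc(C(=O)N/N=C/c3ccccc3O)n(Cc3ccc(Cl)nc3)n2)cc1`, which gives 70000 nM; the only single-change step among the measured compounds is a 1.6-fold higher number from compound 2 to compound 3 (0.19 log units; within the scatter). Farthest from compound 2 stands compound 1 `O=C(N/N=C/c1ccco1)c1cc(-c2ccccc2)nn1Cc1ccccc1`, which gives 12500 nM. Compound 4 `O=C(N/N=C/c1ccccc1O)c1cc(-c2ccccc2)nn1Cc1ccccc1` is not yet measured and differs from compound 2 in one place: phenyl in place of 6-chloropyridin-3-yl on a saturated chain carbon bound to an aromatic nitrogen. Within the data shown here, no measured step bears directly on this change. Among the measured compounds shown here, compound 1 carries the same benzyl group as compound 4 but also a different hydrazone partner, so its two values with compound 2 show only that the benzyl-bearing compound gives the lower number, with two changes at once. The step from compound 2 to compound 3 concerns another part of the molecule and is within the scatter. The expected step in this assay is therefore a 1.8-fold lower number from compound 2 to compound 4 (0.26 log units; within the scatter), modest and uncertain in direction. The estimate for compound 4 is 25000 nM, within 10000 nM to 60000 nM.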

Compound 4, solubility: 44000 nM
For compound 4 the middle estimate is 1.8-fold (0.25 log units) below the measured one, within the range that was stated.
By their numbers in this assay, from the lowest: compound 1; then compounds 4, 2 and 3 (each within the scatter of the next).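

In this assay, replacing (6-chloropyridin-3-yl)methyl with benzyl gives a 1.0-fold lower number from compound 2 to compound 4 (0.01 log units; within the scatter), so on this saturated chain carbon bound to an aromatic nitrogen, the two aromatic groups cannot be told apart. Compound 4 also isolates the change at the carbon with a double bond to nitrogen: 2-hydroxyphenyl in place of furan-2-yl gives a 3.5-fold higher number from compound 1 to compound 4 (0.55 log units; beyond the scatter), so the low number of compound 1 goes with furan-2-yl and not with its benzyl group. Nothing available explains either step.

On these data alone, it remains open whether an amine or a carboxylic acid in place of phenyl on that saturated chain carbon would leave the number just as unmoved. Also open, as far as these compounds go, is whether furan-2-yl would give a step of the same size in a compound carrying 6-chloropyridin-3-yl.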